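A Furan to Hydroxyphenyl Swap on an Inactive Core

The source may report more compounds than this note shows. Statements on the series, on what has been measured and on what is new or still open speak of the compounds shown alone.

Compound 1 `CCOC(=O)c1ccc(N2NC(=O)/C(=C/c3ccco3)C2=O)cc1` was examined in a toxicity assay on HEK293 cells (Homo sapiens) for cytotoxicity; a lower number here means a stronger inhibitor, a higher number a weaker inhibitor. In this assay compound 1 gives > 100000 nM, which is a limit of the assay and not a number. Compound 2 `CN(C)c1ccc(/C=C2/C(=O)NN(c3ccc(Br)cc3)C2=O)cc1` was examined in the same way. In this assay compound 2 gives > 100000 nM, again a limit and not a number. Compound 1 therefore stands at the limit of > 100000 nM in this assay, at which 2 of the 2 values shown sit, and no order between compound 1 and compound 2 can be read from these values.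

Compound 3 `CCOC(=O)c1ccc(N2NC(=O)/C(=C/c3ccccc3O)C2=O)cc1` has not yet been measured in this assay. It differs from compound 1 by 2-hydroxyphenyl in place of furan-2-yl on a double-bonded chain carbon bound to a double-bonded ring carbon, a 2-hydroxyphenyl in place of furan-2-yl on a double-bonded chain carbon bound to a double-bonded ring carbon. Among the measured compounds shown here, no measured step of this kind is available. Given (the limit of > 100000 nM in this assay, at which 2 of the 2 values shown sit), the step of a number no higher from compound 1 to compound 3 (the limit leaves the size open) is expected to be none beyond the scatter. Compound 3 is estimated at 100000 nM, within 30000 nM to 300000 nM, and most likely reported only as a limit.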

Compound 3, half-maximal inhibitory concentration: > 100000 nM
Compound 3: a limit, no number; the forecaster's own chance of this, stated with the estimate: 80%; the middle value lies on the limit itself.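

Compound 3, like compound 1, gives only a limit and not a number, so no step can be read between these two compounds: the limit of > 100000 nM in this assay, at which 3 of the 3 values shown sit. The compounds shown leave open whether 2-hydroxyphenyl in place of furan-2-yl changes anything in this assay.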